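Working notes: compound 3 in the permeability series

The source may hold more compounds than are shown below. What is called first, only, known or untested is meant among the compounds shown, and "the series" means these compounds.

Measured so far, in an ADME assay on Caco-2 cells (Homo sapiens) for permeability, read by LC-MS, in the apical to basolateral direction, with a stated time of 60 min, at pH 6.5; on this read-out higher numbers stand for higher permeability and lower numbers for lower permeability:
- compound 1, `Cc1cccc([C@@H](O)C(=O)N2N=CC[C@H]2C(=O)NCc2cc(Cl)ccc2-n2cnnn2)c1`, gives 9.7 10^-6 cm/s
- compound 2, `CC(C)(C)C[C@@H](O)C(=O)N1C[C@@H]2C[C@@H]2[C@H]1C(=O)NCc1cc(Cl)ccc1-n1cnnn1`, gives 25 10^-6 cm/s

Within the data shown here, compound 1 stands lowest of the two numbers; its gap to compound 2 is beyond the scatter, and the two structures differ in more than one place, so no single step between measured compounds is available.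

Compound 3, `O=C(NCc1cc(Cl)ccc1-n1cnnn1)[C@@H]1CC=NN1C(=O)[C@H](O)C1CCCCC1`, is not yet measured in this assay. Relative to compound 1 the change is cyclohexyl in place of 3-methylphenyl on a saturated chain carbon bound to a carbonyl carbon and an oxygen on a saturated carbon. Among the measured compounds shown here, with no measured step to lean on, the size of the change is open; the expectation is a modest rise, as a 1.3-fold higher number from compound 1 to compound 3 (0.13 log units; within the scatter), not clearly beyond the scatter. For compound 3 in this assay the estimate is 13 10^-6 cm/s, with a range from 6 10^-6 cm/s to 27 10^-6 cm/s.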

Compound 3, apparent permeability: 19 10^-6 cm/s
Compound 3: middle estimate off by 1.5-fold (0.16 log units), on the low side; low and high end bracket the measured number.
By their numbers in this assay, from the lowest: compounds 1, 3 and 2 (each within the scatter of the next, the first and the last beyond it).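

In this assay the series now has its first step between compounds that differ in one place: cyclohexyl in place of 3-methylphenyl gives a 2.0-fold higher number from compound 1 to compound 3 (0.29 log units; within the scatter), on a saturated chain carbon bound to a carbonyl carbon and an oxygen on a saturated carbon. At this position, then, a six-membered non-aromatic ring of carbon only and a six-membered aromatic ring of carbon only cannot be told apart on this read-out, since the step stays within the scatter. No measurement at hand explains the step.

Both groups in this step are carbon-only rings with no hydrogen-bond donors, no hydrogen-bond acceptors and no net charge, so the step says nothing about a piperidine amine or a carboxylic acid at this position. As far as these compounds go, whether a short open chain such as ethyl would stay within the scatter of these rings also remains open.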